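A few compounds are considered here, and "the series" means these few. Any claim that something is new, unique, unknown or untested is made for them only; others in the source may bear on it.

Measured compounds:
Compound 1, `Cc1cccc(NS(=O)(=O)c2ccc(N3CCNC3=O)cc2)c1`, gives 190 nM in a functional assay on MCF7 cells (Homo sapiens) for antiproliferative activity, read by sulforhodamine B assay, with a stated time of 48 h; a higher number here means a weaker inhibitor, a lower number a stronger inhibitor.
Compound 2, `Cc1ccc(NS(=O)(=O)c2ccc(N3CCNC3=O)cc2)cc1C`, gives 230 nM.
Compound 3, `Cc1cc(C)cc(NS(=O)(=O)c2ccc(N3CCNC3=O)cc2)c1`, gives 100 nM.

Compound 3 carries the lowest of the three numbers; compound 1 sits nearest, and the gap between them lies within the scatter, while the step of a 2.3-fold lower number from compound 2 to compound 3 (0.36 log units; beyond the scatter) is the only one that goes beyond it. Compound 4, `COc1ccc(NS(=O)(=O)c2ccc(N3CCNC3=O)cc2)cc1`, is the next member of the series and has not yet been measured. It differs from compound 3 in one place: 4-methoxyphenyl in place of 3,5-dimethylphenyl on a sulfonamide nitrogen.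

For the measured compounds named here, no measured step swaps the whole aryl group on the sulfonamide nitrogen for one bearing a methoxy group, so the bearing of the three known steps is indirect. They show that adding a methyl, as in a 1.2-fold higher number from compound 1 to compound 2 (0.08 log units; within the scatter) and a 1.9-fold lower number from compound 1 to compound 3 (0.28 log units; within the scatter), moves the number little, and that shifting the methyl pattern, as in a 2.3-fold lower number from compound 2 to compound 3 (0.36 log units; beyond the scatter), moves it only modestly. Compound 4 loses both methyls and gains one hydrogen-bond acceptor, a change of a different kind, so the expected step of a 2.0-fold higher number from compound 3 to compound 4 (0.30 log units; within the scatter) is small and its direction uncertain. Compound 4 is therefore estimated at 200 nM, within a range of 80 nM to 600 nM.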

Compound 4, half-maximal inhibitory concentration: > 1000 nM
Compound 4 gave a limit, no number; the forecaster's own chance of this, stated with the estimate: 5%; middle value at least 5.0-fold (0.69 log units) from the limit.
By their numbers in this assay, from the lowest: compounds 3, 1 and 2 (each within the scatter of the next, the first and the last beyond it). At a limit, above all of these: compound 4.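

In this assay, compound 4 carries a limit and not a number: the limit of > 1000 nM in this assay, at which 1 of the 4 values shown sits. For the compounds shown here, the three aryl groups with methyl on the sulfonamide nitrogen had moved the number little among themselves, whereas 4-methoxyphenyl gives an at least 10-fold higher number from compound 3 to compound 4 (1.00 log units; beyond the scatter), an at least 4.3-fold higher number from compound 2 to compound 4 (0.63 log units; beyond the scatter) and an at least 5.2-fold higher number from compound 1 to compound 4 (0.72 log units; beyond the scatter), each larger than any step among the earlier compounds. This position therefore does not tolerate every aryl group alike: 3,5-dimethylphenyl and 4-methoxyphenyl hold the same number of heavy atoms, one of them oxygen in the entering group, and the number still rises beyond the scatter.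

The compounds shown do not separate the oxygen of the methoxy group from the placement of the substituent, since compound 4 differs from each earlier compound in both, and the full size of the loss stays unknown behind the limit. Going by these compounds, how a plain phenyl group, a chlorophenyl group or a dimethoxyphenyl group on the sulfonamide nitrogen would stand in this assay remains open, as does whether any change to the shared core would alter this picture.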